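The compounds below may be only part of what the source reports. "The series", "measured", "known", "first", "only" and "open" are said of these compounds alone.

Measured compounds:
compound 1, `COc1ccc(C)cc1N1C(=O)CSC1c1cccc(C(=O)NCCCCc2ccccc2)c1`, 29%;
compound 2, `Cc1cccc(N2C(=O)CSC2c2cccc(C(=O)NCCCCc3ccccc3)c2)c1`, 71%.

In a functional assay on 143B cells (Homo sapiens) for inhibition, read by CCK-8 assay, with a stated time of 72 h, tested at 1 uM (a higher number here means more inhibition at the concentration tested (going by the name of the read-out), a lower number less inhibition), compound 2 stands highest of the two numbers; its nearest neighbour is compound 1, and the step of a number 42 percentage points higher from compound 1 to compound 2 (beyond the scatter) is large. Compound 3, `CCN1C(=O)CSC1c1cccc(C(=O)NCCCCc2ccccc2)c1`, differs from compound 2 by ethyl in place of 3-methylphenyl on an amide-type nitrogen in a ring. For the measured compounds named here, no measured step bears directly on this change: the one known step only swaps a group on that aryl ring, not the ring itself, yet it shows that this assay answers strongly to changes at this position. A downward step a number 36 percentage points lower from compound 2 to compound 3 (beyond the scatter) is therefore expected, with wide uncertainty. Compound 3 is estimated at 35%, between 5% and 70%.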

Compound 3, a percentage reported as inhibition, at one concentration (the size of the read-out at that concentration, not a potency): 40%
For compound 3 the middle estimate is 5 percentage points below the measured one; the range from low to high includes it.
By their numbers in this assay, from the lowest: compound 1; then compound 3; then compound 2.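

In this assay, ethyl in place of 3-methylphenyl on the ring nitrogen gives a number 31 percentage points lower from compound 2 to compound 3 (beyond the scatter) and shows that compound 3 keeps part of the inhibition without any aromatic ring at this position. Ethyl in place of 2-methoxy-5-methylphenyl gives a number 11 percentage points higher from compound 1 to compound 3 (beyond the scatter) so a ring here can sit above or below ethyl, depending on what it carries. Nothing available explains either step. Still open, as far as these compounds go, is whether an unsubstituted phenyl, a longer chain such as butyl, or a chain ending in an amine would match compound 2 at this position.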